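This account rests on a few compounds, and the source may have more. Where it says the series, first, only, none or still open, it means among the compounds named here.

Compound 1 `CC(/C=C/C=C(\C)c1ccc2c(c1)C(C)(C)CCS2)=C\C(=O)O` gives 12 nM
Compound 2 `CC(/C=C/C=C(\C)c1ccc2c(c1)C(C)(C)CS2)=C\C(=O)O` gives 8 nM
Compound 3 `C/C(=C\c1ccc(C(=O)O)cc1)c1ccc2c(c1)C(C)(C)CO2` gives 460 nM

All three compounds were tested in an assay on CV-1 cells for activation of retinoic acid receptor gamma (Homo sapiens); on this read-out higher numbers stand for an effect only at larger amounts of compound and lower numbers for an effect already at smaller amounts. Compound 1 and compound 2 give the two lower numbers, and the gap between them lies within the scatter. Compound 3 stands apart: in this assay compound 3 gives 460 nM, the highest of the three numbers, a gap beyond the scatter to both compound 1 and compound 2.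

Compound 4 `COC(=O)c1ccc(/C=C(\C)c2ccc3c(c2)C(C)(C)CO3)cc1` has not yet been measured. It differs from compound 3 in one place: methyl in place of hydrogen on an oxygen next to a carbonyl group. For the measured compounds named here, no pair of measured compounds shows this same change, so the size of the step cannot be read from the numbers at hand. The expectation is that compound 4 shows an effect only at larger amounts than compound 3, and this expected step is an 11-fold higher number from compound 3 to compound 4 (1.04 log units; beyond the scatter). For compound 4 the estimated value in this assay is 5000 nM, expected to lie between 1000 nM and 30000 nM.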

Compound 4, half-maximal effective concentration: 400 nM
Compound 4: middle estimate off by 13-fold (1.10 log units), on the high side; the whole stated range lies above it.
By their numbers in this assay, from the lowest: compounds 2 and 1 (each within the scatter of the next); then compounds 4 and 3 (each within the scatter of the next).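

Putting methyl in place of hydrogen on an oxygen next to a carbonyl group, which turns carboxy into methoxycarbonyl, gives a 1.2-fold lower number from compound 3 to compound 4 (0.06 log units; within the scatter) in this assay. For the compounds shown here, for this pair, the two numbers cannot be told apart, so the hydrogen on this oxygen is not needed to keep the number at this level, something no earlier pair could show. Nothing available explains why this change leaves the number in place.

From the compounds shown here alone, whether a longer chain on this oxygen, such as ethyl, or an amide in place of the carboxy group would also leave the number in place remains open. Going by these compounds, it is also open whether the same change would behave alike on the cores of compound 1 and compound 2, which carry a carboxylic acid on a different framework.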